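This account rests on a few compounds, and the source may have more. Where it says the series, first, only, none or still open, it means among the compounds named here.

Compound 3 `CC(C)(C)NCC(=O)N1N=C(c2cc3ccccc3oc2=O)CC1c1ccccc1` stands second highest of the three numbers in a functional assay on PC-3 cells (Homo sapiens) for cytotoxicity, read by MTT assay, with a stated time of 48 h (on this read-out lower numbers stand for stronger inhibition and higher numbers for weaker inhibition), where compound 3 gives 16400 nM. Compound 1 `CCC(=O)N1N=C(c2cc3ccccc3oc2=O)CC1c1ccccc1` gives 4370 nM, and compound 2 `Cc1ccc(S(=O)(=O)N2N=C(c3cc4ccccc4oc3=O)CC2c2ccccc2)cc1` gives 48600 nM. Compound 4 `CC1CC(C)CN(CC(=O)N2N=C(c3cc4ccccc4oc3=O)CC2c2ccccc2)C1` differs from compound 3 in one place: 3,5-dimethylpiperidin-1-yl in place of (tert-butyl)amino on a saturated chain carbon bound to a carbonyl carbon. Among the compounds with values here, the one measured step at that same place is a 3.8-fold higher number from compound 1 to compound 3 (0.57 log units; beyond the scatter); the steps of an 11-fold higher number from compound 1 to compound 2 (1.05 log units; beyond the scatter) and a 3.0-fold lower number from compound 2 to compound 3 (0.47 log units; beyond the scatter) change the group on the ring nitrogen instead and bear only loosely on the present change. With a single step at this position and none that exchanges one amine for another, the expected step in this assay is small, with no clear direction beyond the scatter. Compound 4 is estimated at 12000 nM, between 4000 nM and 40000 nM, an expected step of a 1.4-fold lower number from compound 3 to compound 4 (0.14 log units; within the scatter).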

Compound 4, half-maximal inhibitory concentration: "not active" (no number reported)
No number was reported for compound 4, and the estimate cannot be compared.
By their numbers in this assay, from the lowest: compound 1; then compound 3; then compound 2.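

Within the data shown here, compound 4 is reported as not active, without a number, and no step from compound 3 to it can be read. Nothing shown here offers an explanation for this result. The compounds shown leave open how far 3,5-dimethylpiperidin-1-yl and (tert-butyl)amino differ at this place.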